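Isobutyl on the Oxadiazole of a Desaturase Inhibitor

The source may hold more compounds than are shown below. What is called first, only, known or untested is meant among the compounds shown, and "the series" means these compounds.

Of the compounds shown here, three from this series have been measured in an assay on microsomes from liver for inhibition of acyl-CoA desaturase 1 (Rattus norvegicus); on this read-out higher numbers stand for weaker inhibition and lower numbers for stronger inhibition. Compound 1 `FC(F)(F)c1ccc(OC2CCN(c3ccc(-n4ccnc4)nn3)CC2)cc1` gives 371 nM, compound 2 `FC(F)(F)c1ccccc1OC1CCN(c2ccc(-c3nnco3)nn2)CC1` gives 22 nM, and compound 3 `c1cc(OC2CCN(c3ccc(-n4ccnc4)nn3)CC2)c2cc[nH]c2c1` gives 162 nM. Compound 2 therefore holds the lowest of the three numbers: the nearest, compound 3, stands a good deal higher, beyond the scatter, and compound 1 stands higher still, also beyond the scatter. No two of these compounds differ in a single place, so no individual step can be read from them.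

Compound 4 `CC(C)Cc1nnc(-c2ccc(N3CCC(Oc4ccccc4C(F)(F)F)CC3)nn2)o1` has not yet been measured in this assay . It is derived from compound 2 by a single change: isobutyl in place of hydrogen on an aromatic carbon. The difference, taken one bond further out, reads 1,3,4-oxadiazol-2-yl to 5-isobutyl-1,3,4-oxadiazol-2-yl.

Nothing measured here speaks to a substituent at that position, so the expectation rests on compound 2 alone. The author expects the step of a 1.5-fold lower number from compound 2 to compound 4 (0.17 log units; within the scatter) to be small, at most a modest move toward stronger inhibition, and quite possibly within the scatter. For compound 4 the estimate in this assay is 15 nM, with a range from 4 nM to 60 nM.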

Compound 4, half-maximal inhibitory concentration: 15 nM
Compound 4: middle estimate and measured number agree at the digits printed, within the range that was stated.
By their numbers in this assay, from the lowest: compounds 4 and 2 (each within the scatter of the next); then compound 3; then compound 1.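

Isobutyl in place of hydrogen on this aromatic carbon of the oxadiazole gives a 1.5-fold lower number from compound 2 to compound 4 (0.17 log units; within the scatter) in this assay, so the added group leaves the inhibition of compound 2 essentially unchanged on this read-out. Compound 2 carries only hydrogen at this place, and compounds 1 and 3 do not carry this ring at all, so compound 4 is the first of these compounds to show that the position can hold a substituent, here a branched alkyl one, while the number stays within the scatter of the parent. No evidence is available here that would explain this result.

As far as these compounds go, with compound 4 at 15 nM as the reference, it remains open whether a shorter chain such as methyl, a longer chain, an amine or a carboxylic acid at the same carbon would stay within the scatter of that number. From the compounds shown here alone, it is also open whether isobutyl would give a similar step on an oxadiazole paired with the other ether groups seen in compounds 1 and 3.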